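Removing one trifluoromethyl from a urea end group

A few compounds are considered here, and "the series" means these few. Any claim that something is new, unique, unknown or untested is made for them only; others in the source may bear on it.

Measured compounds:
Compound 1, `O=C(Nc1cccc(-n2cc(-c3ccncc3)c(-c3ccc(Cl)c(O)c3)n2)c1)Nc1cc(C(F)(F)F)cc(C(F)(F)F)c1` — in a functional assay on SN12C cells (Homo sapiens) for inhibition, read by sulforhodamine B assay, with a stated time of 48 h (on this read-out lower numbers stand for higher toxicity in this test and higher numbers for lower toxicity in this test), compound 1 reaches only a limit, > 50000 nM.
Compound 2, `COc1cc(-c2nn(-c3cccc(NC(=O)Nc4ccc(Cl)c(C(F)(F)F)c4)c3)cc2-c2ccncc2)ccc1Cl` — in this assay compound 2 also reaches only a limit, > 32500 nM.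
Compound 3, `COc1cc(-c2nn(-c3cccc(NC(=O)c4ccccc4)c3)cc2-c2ccncc2)ccc1Cl` — in this assay compound 3 likewise reaches only a limit, > 100000 nM.

None of the three values is a number; each is a limit of the test, and the evidence reads (the limit of > 50000 nM in this assay, at which 1 of the 3 values shown sits), the limit of > 32500 nM in this assay, at which 1 of the 3 values shown sits, and (the limit of > 100000 nM in this assay, at which 1 of the 3 values shown sits). Compound 1 therefore stands nowhere in particular among them: no order can be read between these compounds. Among the measured compounds shown here, the one step between neighbours, a step that the two limits leave unreadable from compound 2 to compound 3, is likewise unreadable.

Compound 4, `O=C(Nc1cccc(-n2cc(-c3ccncc3)c(-c3ccc(Cl)c(O)c3)n2)c1)Nc1cccc(C(F)(F)F)c1`, differs from compound 1 by hydrogen in place of trifluoromethyl on an aromatic carbon. For the measured compounds named here, no measured step bears on this change, and the step between compound 2 and compound 3 tells nothing about its size either. With all three measured compounds sitting at limits, the expectation for compound 4 is that it too will most likely reach only a limit in this assay, with no change beyond the scatter. The estimate for compound 4 is 60000 nM, between 20000 nM and 200000 nM, which would mean a step that the limit leaves unreadable from compound 1 to compound 4.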

Compound 4, concentration lethal to 50% of the cells: > 32500 nM
Compound 4 ended at the assay's limit; the forecaster's own chance of this, stated with the estimate: 85%; the middle value does not contradict the limit.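

In this assay compound 4 gives > 32500 nM as a limit, not a number. Compound 1 gives > 50000 nM as a limit too, so the step from one to the other cannot be read. The compounds shown leave open whether hydrogen in place of trifluoromethyl changes this read-out at all, since none of them gives an actual number.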